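From Cyclopropyl to (4-Methoxyphenyl)amino on a Carbonyl Carbon

This account rests on a few compounds, and the source may have more. Where it says the series, first, only, none or still open, it means among the compounds named here.

Of the compounds shown here, three sharing one core have been tested in a functional assay on HT-29 cells (Homo sapiens) for inhibition, read by MTT assay, with a stated time of 48 h; a lower number here means a stronger inhibitor, a higher number a weaker inhibitor. Compound 1 `COc1ccc(CSc2nnc(-c3cc(OC)c(OC)c(OC)c3)n2-c2ccc(N(C)C)cc2)cc1` reaches only a limit of the assay, > 60000 nM. Compound 2 `COc1cc(-c2nnc(SCC(=O)c3ccccc3)n2-c2ccc(N(C)C)cc2)cc(OC)c1OC` gives a true number, 45200 nM. Compound 3 `COc1cc(-c2nnc(SCC(=O)C3CC3)n2-c2ccc(N(C)C)cc2)cc(OC)c1OC` also stands only at a limit of the assay, > 60000 nM.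

Compound 4 `COc1ccc(NC(=O)CSc2nnc(-c3cc(OC)c(OC)c(OC)c3)n2-c2ccc(N(C)C)cc2)cc1` carries (4-methoxyphenyl)amino in place of cyclopropyl on a carbonyl carbon. Going by the values given here, two measured steps bear on this site. Exchanging phenyl for cyclopropyl on the carbonyl carbon gave an at least 1.3-fold higher number from compound 2 to compound 3 (0.12 log units; that floor lies within the scatter). Benzoyl in place of 4-methoxyphenyl gave an at least 1.3-fold lower number from compound 1 to compound 2 (0.12 log units; that floor lies within the scatter). Neither floor goes beyond the scatter, and the wider picture is bounded by the limit of > 60000 nM in this assay, at which 2 of the 3 values shown sit.

Among the compounds with values here, no measured step therefore supports a large change in this assay, and none beyond the scatter is foreseen, with a reading at the limit remaining quite possible. The estimated step is an at least 1.4-fold lower number from compound 3 to compound 4 (0.15 log units; that floor lies within the scatter). Compound 4 is expected at about 42000 nM, with an estimated range from 15000 nM to 60000 nM.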

Compound 4, half-maximal inhibitory concentration: 51400 nM
For compound 4 the middle estimate is 1.2-fold (0.09 log units) below the measured one; the range from low to high includes it.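

In this assay, the (4-methoxyphenyl)amino group, the largest group yet placed on this carbonyl carbon, yields a true number, and the site therefore accepts it without a readable loss or gain. Against the phenyl group, the change gives a 1.1-fold higher number from compound 2 to compound 4 (0.06 log units; within the scatter), so the amino link adds nothing that can be told apart from phenyl alone. The other two steps, an at least 1.1-fold lower number from compound 3 to compound 4 (0.06 log units; that floor lies within the scatter) and an at least 1.1-fold lower number from compound 1 to compound 4 (0.06 log units; that floor lies within the scatter), rest on limits and show no change beyond the scatter either.

The compounds shown leave open whether an aliphatic amine or a carboxylic acid on this carbonyl carbon would move the number beyond the scatter. Whether any group here gives much stronger inhibition also remains unanswered, as the values still crowd the top of the range: the limit of > 60000 nM in this assay, at which 2 of the 4 values shown sit.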